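The source may hold more compounds than are shown below. What is called first, only, known or untested is meant among the compounds shown, and "the series" means these compounds.

Measured compounds:
- compound 1 `C[S+]([O-])c1c(F)c(N)c2c(=O)cc(-c3ccc(N)c(F)c3)oc2c1F`: 2500 nM
- compound 2 `Nc1ccc(-c2cc(=O)c3c(N)c(F)c(CO)c(F)c3o2)cc1F`: 62 nM
- compound 3 `Nc1ccc(-c2cc(=O)c3c(N)c(F)c(Cl)c(F)c3o2)cc1F`: 210 nM

In a functional assay on MCF7 cells (Homo sapiens) for cytotoxicity, read by neutral red uptake, with a stated time of 3 days (on this read-out lower numbers stand for stronger inhibition and higher numbers for weaker inhibition), compound 2 gives the lowest number of the three, at 62 nM. The nearest measured neighbour is compound 3, which in this assay gives 210 nM, and the furthest is compound 1, which gives 2500 nM. The step of a 3.4-fold higher number from compound 2 to compound 3 (0.53 log units; beyond the scatter) and the step of a 40-fold lower number from compound 1 to compound 2 (1.61 log units; beyond the scatter) both show that what sits at this position of the shared core moves the number well beyond the scatter.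

Compound 4 `CCCOCc1c(F)c(N)c2c(=O)cc(-c3ccc(N)c(F)c3)oc2c1F` keeps the rest of compound 2 and differs only in one place: propyl in place of hydrogen on an oxygen on a saturated carbon. Among the compounds with values here, no measured step bears directly on this change, since every measured step alters the group on the aromatic carbon itself rather than what sits on the oxygen of the hydroxymethyl group. The measured steps only show that this position is sensitive. On that basis a modest step is expected in this assay, toward a higher number, with wide uncertainty; the expected step is a 2.4-fold higher number from compound 2 to compound 4 (0.38 log units; beyond the scatter). Compound 4 is therefore estimated at 150 nM, within the range 50 nM to 600 nM.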

Compound 4, half-maximal inhibitory concentration: 1200 nM
Compound 4: the middle estimate sits 8.0-fold (0.90 log units) below what was measured; measured number above the stated range.
By their numbers in this assay, from the lowest: compound 2; then compound 3; then compound 4; then compound 1.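

In this assay, putting propyl on the oxygen of the hydroxymethyl group is a large change in its own right (a 19-fold higher number from compound 2 to compound 4 (1.29 log units; beyond the scatter)), so the number responds not only to the group on the aromatic carbon but also to what sits on that oxygen. The propoxymethyl group also compares poorly with chloro (a 5.7-fold higher number from compound 3 to compound 4 (0.76 log units; beyond the scatter)) and keeps only a modest edge over the group carried by compound 1 (a 2.1-fold lower number from compound 1 to compound 4 (0.32 log units; beyond the scatter)). Among these four compounds, the free hydroxymethyl of compound 2 therefore remains the group with the lowest number.

From the compounds shown here alone, whether methoxymethyl, aminomethyl or a carboxylic acid at this position would stay near compound 2 remains open. Nothing given here accounts for the size of the step from hydroxy to propoxy.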